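The compounds below may be only part of what the source reports. "The series", "measured", "known", "first", "only" and "open" are said of these compounds alone.

- compound 1 `NC1C[C@@H](N)[C@@H](O)C(O)[C@H]1OCSc1ccnc2cc(C(F)(F)F)ccc12`: 35000 nM
- compound 2 `NCCCNCCOC1[C@@H](OCSc2ccnc3cc(C(F)(F)F)ccc23)C(N)C[C@@H](N)[C@H]1O`: 2000 nM

In an assay on nucleic acid with ribosomal RNA A-site as the target (on this read-out higher numbers stand for weaker binding and lower numbers for tighter binding), compound 1 holds the higher of the two numbers, so it is the weaker binder of the pair. Compound 3 `CN(C)CCCNC(=O)CO[C@H]1C(O)[C@@H](OCSc2ccnc3cc(C(F)(F)F)ccc23)C(N)C[C@H]1N` is still unmeasured. It keeps the core of compound 1 and places ((3-(dimethylamino)propyl)carbamoyl)methyl in place of hydrogen on an oxygen on a saturated carbon.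

Among the compounds with values here, one measured step bears on this change: an 18-fold lower number from compound 1 to compound 2 (1.24 log units; beyond the scatter). That large step, beyond the scatter, also replaced hydrogen on an oxygen on a saturated carbon, but with 2-((3-aminopropyl)amino)ethyl. The entering groups differ, so the comparison is only partial, and a smaller move in the same direction is expected in this assay. The expected step is a 4.4-fold lower number from compound 1 to compound 3 (0.64 log units; beyond the scatter). For compound 3 the estimate is 8000 nM, with an expected range from 2000 nM to 30000 nM.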

Compound 3, dissociation constant: 241000 nM
Beside the measured number, compound 3's estimate is 30-fold (1.48 log units) below it, outside the stated range (above it).
By their numbers in this assay, from the lowest: compound 2; then compound 1; then compound 3.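

In this assay, putting a chain on this oxygen does not always tighten binding: ((3-(dimethylamino)propyl)carbamoyl)methyl gives a 6.9-fold higher number from compound 1 to compound 3 (0.84 log units; beyond the scatter), whereas 2-((3-aminopropyl)amino)ethyl gives an 18-fold lower number from compound 1 to compound 2 (1.24 log units; beyond the scatter). The direction of the change at this position therefore depends on which group enters, not merely on replacing the hydrogen. No supporting data are available to explain this reversal.

The two chains differ in several features at once, and the carbonyl and the amide hydrogen occur only in the chain of compound 3, so the compounds shown cannot tell which feature sets the direction. A simple 3-(dimethylamino)propyl chain on the same oxygen, or a carbamoylmethyl chain ending in a primary amine, would help separate those features.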